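This account rests on a few compounds, and the source may have more. Where it says the series, first, only, none or still open, it means among the compounds named here.

- compound 1 `CC(=O)N1N=C(c2ccc3ccccc3c2)OC1c1cccc(Br)c1` gives 1.68 ug/mL in the test below
- compound 2 `CC(=O)N1N=C(c2ccc3ccccc3c2)OC1c1ccccc1[N+](=O)[O-]` gives 12.3 ug/mL in the same test

In a functional assay on HepG2 cells (Homo sapiens) for antiproliferative activity, read by MTT assay, with a stated time of 48 h (on this read-out lower numbers stand for stronger inhibition and higher numbers for weaker inhibition), compound 2 gives 12.3 ug/mL as the higher of the two numbers, which makes it the weaker inhibitor of the pair. The next change leads to compound 3 `CC(=O)N1N=C(c2ccc3ccccc3c2)OC1c1ccccn1` and is pyridin-2-yl in place of 2-nitrophenyl on a saturated ring carbon, with pyridin-2-yl in place of 2-nitrophenyl on a saturated ring carbon. Among the measured compounds shown here, only one measured step bears on this: a 7.3-fold higher number from compound 1 to compound 2 (0.86 log units; beyond the scatter) is modest but beyond the scatter, and it shows that the group at this carbon can move the number. It involves a different pair of groups, so it indicates a possible size and not a direction. Compound 1 at 1.68 ug/mL shows that a lower number is reachable, so a small downward move is expected, probably within the scatter. The estimated step is a 1.5-fold lower number from compound 2 to compound 3 (0.19 log units; within the scatter) for this change. For compound 3 the expected value is 8 ug/mL, with an estimated range from 2 ug/mL to 30 ug/mL in this assay.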

Compound 3, half-maximal inhibitory concentration: 5.26 ug/mL
Compound 3: the middle estimate sits 1.5-fold (0.18 log units) above what was measured; the range from low to high includes it.
By their numbers in this assay, from the lowest: compound 1; then compound 3; then compound 2.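

In this assay, the group on this saturated ring carbon need not be a substituted carbon-only ring to give a measurable number, and the pyridin-2-yl of compound 3 gives a 2.3-fold lower number from compound 2 to compound 3 (0.37 log units; beyond the scatter) as the step away from 2-nitrophenyl. The same group does not reach the level of 3-bromophenyl, with a 3.1-fold higher number from compound 1 to compound 3 (0.50 log units; beyond the scatter) as the matching step, so all three groups now stand apart by more than the scatter and compound 1 remains the strongest inhibitor of the set. No measured information is available that could explain this order.

The compounds shown leave open how a plain phenyl would compare with pyridin-2-yl, and whether pyridin-3-yl or pyridin-4-yl would give a similar number. They also leave open how a group without an aromatic ring, such as a simple amine or a carboxylic acid, would behave on this carbon.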